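Swapping Cyclohexyl for Pyridin-3-yl in Compound 1

The source may report more compounds than this note shows. Statements on the series, on what has been measured and on what is new or still open speak of the compounds shown alone.

Compound 1 `O=C(CN1CCN(C2CCCCC2)CC1)Nc1nc2c(s1)CCCC2` was tested in an assay on isolated protein for inhibition of long-chain fatty acid transport protein 1 (Homo sapiens), read by scintillation counting, with a stated time of 20 min; on this read-out higher numbers stand for weaker inhibition and lower numbers for stronger inhibition. For compound 1 the result is only a limit, > 1000 nM. Compound 2 `O=C(CN1CCN(c2cccc(F)c2)CC1)Nc1nc2c(s1)CCCC2` likewise returns only a limit, > 1000 nM. Compound 3 `O=C(CN1CCN(c2nccs2)CC1)Nc1nc2c(s1)CCCC2` gives 520 nM. Two of the three values sit at the limit of > 1000 nM in this assay, at which 2 of the 3 values shown sit, so compound 1 stands at the weak end of what can be seen. Compound 4 `O=C(CN1CCN(c2cccnc2)CC1)Nc1nc2c(s1)CCCC2` carries the change (pyridin-3-yl in place of cyclohexyl on an amine nitrogen in a ring). The closest measured step, an at least 1.9-fold lower number from compound 1 to compound 3 (0.28 log units; that floor lies within the scatter), also replaced cyclohexyl with a heteroaromatic ring, while a step that the two limits leave unreadable from compound 1 to compound 2 has no readable size. A comparable lowering is therefore expected in this assay for compound 4, though the floor of that step lies within the scatter. The estimate for compound 4 is 700 nM, between 300 nM and 2000 nM. The step this estimate implies is expected to be an at least 1.4-fold lower number from compound 1 to compound 4 (0.15 log units; that floor lies within the scatter).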

Compound 4, half-maximal inhibitory concentration: > 1000 nM
Compound 4 was reported as a limit (the forecaster's own chance of this, stated with the estimate: 40%); middle value at least 1.4-fold (0.15 log units) away from the limit.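

Compound 4 is again only a limit, so a heteroaromatic ring on this amine nitrogen does not always give a readable number in this assay. Replacing 1,3-thiazol-2-yl with pyridin-3-yl gives an at least 1.9-fold higher number from compound 3 to compound 4 (0.28 log units; that floor lies within the scatter), so even this comparison does not clear the scatter. The steps to compound 4 from compound 1 and from compound 2 cannot be read, with both ends limits: the limit of > 1000 nM in this assay, at which 3 of the 4 values shown sit.

Going by these compounds, it remains open whether pyrimidin-2-yl or 1,3-oxazol-2-yl in this place would give a number rather than a limit. On these data alone, how far compound 1, compound 2 and compound 4 differ from one another also stays open.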